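Sulfur substituent change in the nucleoside series

The source may hold more compounds than are shown below. What is called first, only, known or untested is meant among the compounds shown, and "the series" means these compounds.

Going by the values given here, in an assay on isolated protein for binding affinity to Equilibrative nucleoside transporter 1 (Homo sapiens) (on this read-out higher numbers stand for weaker inhibition and lower numbers for stronger inhibition), compound 2 `CCC(C)Sc1nc(N)nc2c1ncn2[C@@H]1O[C@H](CO)[C@@H](O)[C@H]1O` gives 63100 nM, the second highest of the three numbers known. Compound 3 `CCCn1cnc2c(SC(C)C)nc(N)nc21` gives 145000 nM, and compound 1 `CCCCSc1nc(N)nc2c1ncn2[C@@H]1O[C@H](CO)[C@@H](O)[C@H]1O` gives 12000 nM. Compound 4 `Cc1cccc(CSc2nc(N)nc3c2ncn3[C@@H]2O[C@H](CO)[C@@H](O)[C@H]2O)n1` differs from compound 2 by (6-methylpyridin-2-yl)methyl in place of sec-butyl on a sulfur. Among the compounds with values here, the only measured step at this sulfur is a 5.3-fold higher number from compound 1 to compound 2 (0.72 log units; beyond the scatter), in which sec-butyl replaced butyl; the same sec-butyl is what leaves on the way to compound 4, so reversing that loss seems plausible, while nothing measured speaks to the (6-methylpyridin-2-yl)methyl group itself. A step of a 6.3-fold lower number from compound 2 to compound 4 (0.80 log units; beyond the scatter) is therefore expected, towards a stronger number. Compound 4 is estimated at 10000 nM, within 1500 nM to 60000 nM.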

Compound 4, half-maximal inhibitory concentration: 11500000 nM
Compound 4: the middle estimate sits 1200-fold (3.06 log units) below what was measured; the measured number lies above the stated range.
By their numbers in this assay, from the lowest: compound 1; then compound 2; then compound 3; then compound 4.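

The sulfur position is far less forgiving than the two alkyl compounds suggested: the change to (6-methylpyridin-2-yl)methyl gives a 180-fold higher number from compound 2 to compound 4 (2.26 log units; beyond the scatter) and exceeds the branching step, a 5.3-fold higher number from compound 1 to compound 2 (0.72 log units; beyond the scatter), in size. Measured against the straight chain, the change reads a 960-fold higher number from compound 1 to compound 4 (2.98 log units; beyond the scatter), which places both alkyl compounds well on the stronger side of compound 4. Nothing available accounts for the size of this drop.

Going by these compounds, whether the ring or its methyl carries the loss remains open. An unsubstituted benzyl group or a longer alkyl chain such as pentyl on the sulfur would help separate these.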